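The source may hold more compounds than are shown below. What is called first, only, known or untested is meant among the compounds shown, and "the series" means these compounds.

Measured so far:
- Compound 1, `COc1ccc(C(=O)NC(CCN(C)C)c2ccc(Cl)cc2)cc1`, 1350 nM
- Compound 2, `Cc1c(Cl)cccc1C(=O)NC(CCN(C)C)c1ccc(Cl)cc1`, 1740 nM
- Compound 3, `Cc1ccc(C)c(C(=O)NC(CCN(C)C)c2ccc(Cl)cc2)c1`, 2880 nM

These three compounds share a core and differ only in the aryl group on the carbonyl carbon. In an assay on NIH3T3 cells with Urotensin-2 receptor (Homo sapiens) as the target (a higher number here means that more compound is needed for the effect, a lower number that less compound is needed), compound 1 gives 1350 nM, compound 2 gives 1740 nM and compound 3 gives 2880 nM. Compound 3 thus has the highest number of the three; against compound 2 the difference is within the scatter (a 1.7-fold higher number from compound 2 to compound 3 (0.22 log units; within the scatter)), against compound 1 it is modest but beyond it (a 2.1-fold higher number from compound 1 to compound 3 (0.33 log units; beyond the scatter)), and the step of a 1.3-fold higher number from compound 1 to compound 2 (0.11 log units; within the scatter) is within the scatter.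

Compound 4, `Cc1ccc(C(=O)NC(CCN(C)C)c2ccc(Cl)cc2)c(C)c1`, is the next step from compound 3: 2,4-dimethylphenyl in place of 2,5-dimethylphenyl on a carbonyl carbon. All three measured steps concern exchanges of the aryl group on the carbonyl carbon, and all were small, from within the scatter to a modest change. For compound 4 a step of a 1.2-fold lower number from compound 3 to compound 4 (0.06 log units; within the scatter) is therefore expected in this assay, that is, none beyond the scatter in either direction. Compound 4 is estimated at 2500 nM, within 1200 nM to 5200 nM.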

Compound 4, half-maximal effective concentration: 1550 nM
The estimate for compound 4 lay 1.6-fold (0.21 log units) above the measured number, within the range that was stated.
By their numbers in this assay, from the lowest: compounds 1, 4, 2 and 3 (each within the scatter of the next, the first and the last beyond it).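

Exchanging 2,5-dimethylphenyl for 2,4-dimethylphenyl on the carbonyl carbon leaves the atoms unchanged and only joins them differently, and in this assay this gives a step within the scatter (a 1.9-fold lower number from compound 3 to compound 4 (0.27 log units; within the scatter)). Compound 4 also stays within the scatter of the two remaining compounds (a 1.1-fold lower number from compound 2 to compound 4 (0.05 log units; within the scatter); a 1.1-fold higher number from compound 1 to compound 4 (0.06 log units; within the scatter)), so all four aryl groups fall in a narrow band, and only the gap between compound 1 and compound 3 exceeds the scatter. Nothing available explains these small differences.

As far as these compounds go, whether an amine or a carboxylic acid on this aryl group would move the number much further remains open. The rest of the shared core is the same in all four compounds, so the effect of a longer chain there is also unknown.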